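The compounds below may be only part of what the source reports. "The series", "measured", "known", "first", "only" and "open" are said of these compounds alone.

Measured compounds:
compound 1 `CN(C(=S)SCc1ccc(C(=O)Nc2ccccc2N)cc1)c1cccnc1`, which in a functional assay on MGC-803 cells (Homo sapiens) for antiproliferative activity, read by CCK-8 assay, with a stated time of 72 h, tested at 2 uM (a lower number here means a weaker effect, a higher number a stronger effect of the compound at the concentration tested), gives 46.1%;
compound 2 `CC1CCCCN1C(=S)SCc1ccc(C(=O)Nc2ccccc2N)cc1`, which in this assay gives 64.4%.

Compound 2 stands highest of the two numbers; its nearest neighbour is compound 1, the step of a number 18.3 percentage points higher from compound 1 to compound 2 (beyond the scatter) lying beyond the usual scatter. Compound 3 `CCN(Cc1ccncc1)C(=S)SCc1ccc(C(=O)Nc2ccccc2N)cc1` has not yet been measured. It differs from compound 2 in one place: ethyl((pyridin-4-yl)methyl)amino in place of 2-methylpiperidin-1-yl on a thiocarbonyl carbon. For the measured compounds named here, the only measured step that bears on this change is the one from compound 1 to compound 2, where a pyridine-bearing acyclic amine gave way to the saturated ring and the number rose modestly. Compound 3 returns to an acyclic amine carrying a pyridine, so a step back downward, of a size similar to that earlier step, is expected in this assay, as a number 14.4 percentage points lower from compound 2 to compound 3 (beyond the scatter). Compound 3 is therefore estimated at 50%, within a range of 34% to 66%.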

Compound 3, a percentage reported as inhibition, at one concentration (the size of the read-out at that concentration, not a potency): 71.6%
Compound 3: middle estimate off by 21.6 percentage points, on the low side, outside the stated range (above it).
By their numbers in this assay, from the lowest: compound 1; then compounds 2 and 3 (each within the scatter of the next).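

With a number 7.2 percentage points higher from compound 2 to compound 3 (within the scatter) in this assay, the acyclic ethyl((pyridin-4-yl)methyl)amino group and the saturated 2-methylpiperidin-1-yl ring cannot be told apart on this thiocarbonyl carbon. A pyridine ring on an acyclic amine therefore does not by itself hold the number down at this position. With a number 25.5 percentage points higher from compound 1 to compound 3 (beyond the scatter), the two pyridine-bearing amines also prove not to be interchangeable, so the make-up of the whole amine matters here, not merely the presence of a pyridine ring.

Nothing available accounts for this difference. Still open, going by these compounds, is whether the pyridine ring contributes at all, which a benzyl group in its place on the ethyl-substituted amine would test, and how a morpholine ring or a simple dimethylamino group would fare at this carbon.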